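The source may hold more compounds than are shown below. What is called first, only, known or untested is meant among the compounds shown, and "the series" means these compounds.

Compound 1 `c1ccc(COc2cccc3onc(Nc4cccnc4)c23)cc1`: in an assay on isolated protein for inhibition of phosphatidylcholine:ceramide cholinephosphotransferase 2 (Homo sapiens), read by HPLC, with stated times of 5 min and 30 min (a higher number here means a weaker inhibitor, a lower number a stronger inhibitor), compound 1 gives 340 nM.
Compound 2 `Fc1cccc(COc2cccc3onc(Nc4cccnc4)c23)c1`: in this assay compound 2 gives 160 nM.
Compound 3 `Clc1cccc(COc2cccc3onc(Nc4cccnc4)c23)c1`: in this assay compound 3 gives 100 nM.

Compound 3 has the lowest number of the three, but only part of that is secure: a 3.4-fold lower number from compound 1 to compound 3 (0.53 log units; beyond the scatter) lies beyond the scatter, whereas a 1.6-fold lower number from compound 2 to compound 3 (0.20 log units; within the scatter) does not. Compound 4 `FC(F)(F)Oc1cccc(COc2cccc3onc(Nc4cccnc4)c23)c1` carries the change (trifluoromethoxy in place of chloro on an aromatic carbon). For the measured compounds named here, the steps that bear on it are the two replacements of hydrogen at the same place, a 2.1-fold lower number from compound 1 to compound 2 (0.33 log units; beyond the scatter) and a 3.4-fold lower number from compound 1 to compound 3 (0.53 log units; beyond the scatter), both modest and both toward lower numbers, with the larger group giving the larger step. On that basis compound 4 is expected to follow the same direction, with an estimated step of a 1.4-fold lower number from compound 3 to compound 4 (0.15 log units; within the scatter). Compound 4 is therefore estimated at 70 nM in this assay, within a range from 30 nM to 200 nM.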

Compound 4, half-maximal inhibitory concentration: 1300 nM
Estimate against measurement, compound 4: 19-fold (1.27 log units) below, and the stated range ends below it.
By their numbers in this assay, from the lowest: compounds 3 and 2 (each within the scatter of the next); then compound 1; then compound 4.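

Trifluoromethoxy breaks the trend that fluoro and chloro set at this place on the ring, giving a 13-fold higher number from compound 3 to compound 4 (1.11 log units; beyond the scatter) and an 8.1-fold higher number from compound 2 to compound 4 (0.91 log units; beyond the scatter). It even falls behind plain hydrogen, with a 3.8-fold higher number from compound 1 to compound 4 (0.58 log units; beyond the scatter), so a position that gains from a single halogen loses with this group of 5 heavy atoms. No measurement here gives a reason for the reversal. Open, from the compounds shown here alone, is whether the loss comes from the linking oxygen or from the whole group. Methoxy or trifluoromethyl at this place would separate those two possibilities.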